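The source may report more compounds than this note shows. Statements on the series, on what has been measured and on what is new or still open speak of the compounds shown alone.

In a functional assay on L1210 cells (Mus musculus) for inhibition, read by cell counting, with a stated time of 2 days (on this read-out higher numbers stand for weaker inhibition and lower numbers for stronger inhibition), three compounds have been measured. Compound 1 `C=C(Br)C(=O)Nc1cccc(-c2cn3nc(Cc4ccc(OC)cc4)sc3n2)c1` gives 1400 nM. Compound 2 `Nc1cccc(-c2cn3nc(Cc4ccccc4)sc3n2)c1` gives 7400 nM. Compound 3 `Nc1cccc(-c2cn3nc(CCc4ccccc4)sc3n2)c1` gives 31000 nM.

Going by the values given here, compound 3 stands highest of the three, weakest on this read-out; the only single-change step that reaches it is a 4.2-fold higher number from compound 2 to compound 3 (0.62 log units; beyond the scatter), and compound 1 lies lower still.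

Compound 4 `COc1ccc(Cc2nn3cc(-c4cccc(N)c4)nc3s2)cc1` differs from compound 3 in one place: 4-methoxyphenyl in place of benzyl on a saturated chain carbon bound to an aromatic carbon. Among the compounds with values here, the one step that bears on this is a 4.2-fold higher number from compound 2 to compound 3 (0.62 log units; beyond the scatter), which shows a benzyl lengthening the chain and weakening inhibition modestly; the present change shortens it back to an aryl group, so a downward step of roughly that size is expected. Compound 4 is therefore expected at 6000 nM, between 2500 nM and 15000 nM. For compound 4 this means an expected step of a 5.2-fold lower number from compound 3 to compound 4 (0.71 log units; beyond the scatter).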

Compound 4, half-maximal inhibitory concentration: 227000 nM
The estimate for compound 4 lay 38-fold (1.58 log units) below the measured number, and the stated range ends below it.
By their numbers in this assay, from the lowest: compound 1; then compound 2; then compound 3; then compound 4.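

In this assay methoxy in place of hydrogen on an aromatic carbon gives a 31-fold higher number from compound 2 to compound 4 (1.49 log units; beyond the scatter) and so counts as a large loss, and the shorter chain brings no recovery: 4-methoxyphenyl in place of benzyl gives a 7.3-fold higher number from compound 3 to compound 4 (0.86 log units; beyond the scatter) even though the earlier chain step pointed the other way. Hydrogen in place of (1-bromoethenyl)carbonyl on the nitrogen gives a 160-fold higher number from compound 1 to compound 4 (2.21 log units; beyond the scatter) in the same series. On these data alone, whether a hydroxyl or a fluorine on that aromatic carbon would follow methoxy remains open, as does whether a plain acetyl on the nitrogen would match the (1-bromoethenyl)carbonyl group. Nothing measured here accounts for these steps.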